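Benzyl amide replaces hexyl amide in writhing test

A few compounds are considered here, and "the series" means these few. Any claim that something is new, unique, unknown or untested is made for them only; others in the source may bear on it.

Compound 3 `CCCCCCNC(=O)CC1CCc2cc(OC)c(OC)cc21` gives 82.2% in a functional assay on the whole organism (strain Swiss albino) for inhibition, with Mus musculus as the target, in the writhing test, with stated times of 60 min and 15 min, at a dose of 100 mg/kg by the oral route (on this read-out higher numbers stand for more inhibition at the one dose given (going by the name of the read-out) and lower numbers for less inhibition), and stands highest of the three compounds measured. Compound 2 `COc1cc2c(cc1OC)C(CC(=O)N(C)C)CC2` is nearest, giving 22.6% in this assay, and compound 1 `CNC(=O)CC1CCc2cc(OC)c(OC)cc21` is furthest, giving 21.2%. The two steps leading to compound 3 are both large: a number 61 percentage points higher from compound 1 to compound 3 (beyond the scatter), and a number 59.6 percentage points higher from compound 2 to compound 3 (beyond the scatter), whereas the small step of a number 1.4 percentage points higher from compound 1 to compound 2 (within the scatter) stays within the scatter. Both large gains came from adding a longer chain on the amide-type nitrogen.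

Compound 4 `COc1cc2c(cc1OC)C(CC(=O)NCc1ccccc1)CC2` differs from compound 3 in one place: phenyl in place of pentyl on a saturated chain carbon bound to an amide-type nitrogen. Within the data shown here, no measured step tells how an aromatic ring on this saturated chain carbon behaves; the only steps available concern a hexyl chain against hydrogen or methyl. On these data alone, because compound 3 with its hexyl chain reached 82.2% while the small groups of compounds 1 and 2 stayed low, a benzyl group is expected to keep much of the gain, though a drop is plausible since the change is untested. The expected step is a number 22.2 percentage points lower from compound 3 to compound 4 (beyond the scatter), and compound 4 is estimated at 60%, with a range from 30% to 88%.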

Compound 4, a percentage reported as inhibition, in the whole organism at one dose (the size of the read-out at that dose, not a potency): 48.1%
Estimate against measurement, compound 4: 11.9 percentage points above; the measured number falls inside the stated range.
By their numbers in this assay, from the lowest: compounds 1 and 2 (each within the scatter of the next); then compound 4; then compound 3.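

On the saturated chain carbon bound to an amide-type nitrogen, an aromatic ring can take the place of a chain, but in this assay the change from pentyl to phenyl gives up a large part of the hexyl amide's number (a number 34.1 percentage points lower from compound 3 to compound 4 (beyond the scatter)). The benzyl amide still stands clearly above both small amides, by modest steps (a number 25.5 percentage points higher from compound 2 to compound 4 (beyond the scatter); a number 26.9 percentage points higher from compound 1 to compound 4 (beyond the scatter)), so the gain at this position is not confined to a hexyl chain, although hexyl remains the better of the two larger groups. Nothing measured here accounts for the difference between the hexyl and benzyl groups.

The compounds shown leave open whether a saturated cyclohexylmethyl group would score nearer to hexyl or to benzyl, and how a phenylethyl amide, a longer octyl chain or a benzyl ring carrying a methoxy group or chlorine would fare. On these data alone, each compound is also seen at a single dose, so whether this order would hold at other doses remains unknown.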